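This account rests on a few compounds, and the source may have more. Where it says the series, first, only, none or still open, it means among the compounds named here.

Measured in an ADME assay on Vero cells (Chlorocebus sabaeus) for cytotoxicity, read by MTT assay, with a stated time of 48 h; a higher number here means that more compound is tolerated, a lower number that less compound is tolerated:

- compound 1 `O=C(NCc1ccc(-c2ccc(Cl)cc2)cc1)c1ccc([N+](=O)[O-])o1`: 4400 nM
- compound 2 `O=C(NCc1ccc(Oc2ccc(Cl)cc2)cc1)c1ccc([N+](=O)[O-])o1`: 8400 nM
- compound 3 `CC(C)(NC(=O)c1ccc([N+](=O)[O-])o1)c1ccc(-c2ccc(Cl)cc2)cc1`: a limit, > 140000 nM

Compound 1 and compound 2 share a core and differ by 4-chlorophenoxy in place of 4-chlorophenyl on an aromatic carbon; the step is a 1.9-fold higher number from compound 1 to compound 2 (0.28 log units; within the scatter), so the two values cannot be told apart in this assay. Compound 3 carries a different core; the difference between the core of compound 1 and the core of compound 3 is not broken down here. For compound 3 this assay gives only a limit, (the limit of > 140000 nM in this assay, at which 1 of the 3 values shown sits), so no number is available for it.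

Compound 4 `CC(C)(NC(=O)c1ccc([N+](=O)[O-])o1)c1ccc(Oc2ccc(Cl)cc2)cc1` is not yet measured. It stands to compound 3 as compound 2 stands to compound 1: the change is 4-chlorophenoxy in place of 4-chlorophenyl on an aromatic carbon, the same change with the same surroundings at the place of exchange. Beside the measured step from compound 1 to compound 2, the step from compound 3 to compound 4 is expected to be a step that the limit leaves unreadable from compound 3 to compound 4, resting on that earlier step being within the scatter and on compound 3 sitting at the limit. Compound 4 is therefore estimated at 180000 nM in this assay, between 70000 nM and 400000 nM.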

Compound 4, half-maximal cytotoxic concentration: 67000 nM
The estimate for compound 4 lay 2.7-fold (0.43 log units) above the measured number, outside the stated range (below it).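

In this assay, 4-chlorophenoxy in place of 4-chlorophenyl on the core of compound 3 gives an at least 2.0-fold lower number from compound 3 to compound 4 (0.32 log units; beyond the scatter). Set beside the same exchange on the core of compound 1, the step does not carry over from one core to the other in size: the same change on two cores in this assay, a 1.9-fold higher number (0.28 log units; within the scatter) from compound 1 to compound 2 and an at least 2.0-fold lower number (0.32 log units; beyond the scatter) from compound 3 to compound 4, at least 3.9-fold (0.60 log units) apart, beyond the scatter of two such steps Compound 3 rests at a limit of the assay and not at a number, so the size of the new step stays a bound, and two cores show nothing about how the change would behave on a third core: the limit of > 140000 nM in this assay, at which 1 of the 4 values shown sits.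

The compounds shown leave open which part of the difference between the two cores goes with the gap between the two steps. Also open, going by these compounds, is how this assay would read with an amine or a carboxylic acid in place of the chlorine of the 4-chlorophenoxy group, or with a longer chain in place of the oxygen link.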